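One halogen swap on a cytotoxic compound

This account rests on a few compounds, and the source may have more. Where it says the series, first, only, none or still open, it means among the compounds named here.

- compound 1 `O=C(CSC(=S)N[C@H]1CCOC1=O)Nc1cccc(C(F)(F)F)c1` gives > 128000 nM as a limit
- compound 2 `O=C(CCl)Nc1ccc(C(=O)/C=C/c2ccc(Br)cc2)cc1` gives 13300 nM as a number

Going by the values given here, in a functional assay on SMMC-7721 cells (Homo sapiens) for cytotoxicity, read by MTT assay, with a stated time of 72 h (on this read-out higher numbers stand for weaker inhibition and lower numbers for stronger inhibition), compound 2 gives 13300 nM as the only true number so far. Compound 1 reads > 128000 nM in this assay and that entry is a limit of the assay, not a number.

Compound 3 `O=C(CCl)Nc1ccc(C(=O)/C=C/c2cccc(Cl)c2)cc1` has not yet been measured. It differs from compound 2 by 3-chlorophenyl in place of 4-bromophenyl on a double-bonded chain carbon bound to a double-bonded chain carbon and so carries 3-chlorophenyl in place of 4-bromophenyl on a double-bonded chain carbon bound to a double-bonded chain carbon. Among the compounds with values here, the two measured compounds differ in more than one place, so no measured step shows what such a swap does. The expected change in this assay is therefore none beyond the usual scatter, with no direction favoured. This expectation rests on compound 2 at 13300 nM as the only anchor. The expected 1.1-fold higher number from compound 2 to compound 3 (0.05 log units; within the scatter) is small. Compound 3 is expected at 15000 nM within a range from 6000 nM to 40000 nM on this estimate.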

Compound 3, half-maximal inhibitory concentration: 7760 nM
For compound 3 the middle estimate is 1.9-fold (0.29 log units) above the measured one; the range from low to high includes it.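

In this assay, placing 3-chlorophenyl where 4-bromophenyl stood on a double-bonded chain carbon bound to a double-bonded chain carbon gives a 1.7-fold lower number from compound 2 to compound 3 (0.23 log units; within the scatter). Going by these compounds alone, this is the first step that isolates a single place in these molecules, and it shows that this particular exchange, in which both the halogen and its printed ring number differ, cannot be told apart from repeat-measurement noise, so the two compounds read as equivalent here. Compound 1 alone stands at a limit of the assay, which is not a number, so it offers no comparison for this step: the limit of > 128000 nM in this assay, at which 1 of the 3 values shown sits.

Within the data shown here, the single step changes the halogen and its ring number together, so 4-chlorophenyl or 3-bromophenyl would be needed to tell whether either change alone matters, and two compounds reading alike cannot show whether the two differences have no effect or happen to offset each other. Going by these compounds, it also remains open whether the reading would hold with a group of a different kind on that ring, such as an amine or a carboxylic acid, in place of the halogen.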